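Restoring the Benzyl Amide Side Chain in Compound 4

The source may hold more compounds than are shown below. What is called first, only, known or untested is meant among the compounds shown, and "the series" means these compounds.

Measured compounds:
compound 1, `COc1ccc(CC(C)C(=O)N2CCN(c3ccc(C(F)(F)F)cc3[C@@H](N)CC(C)C)CC2)cc1`, this assay: 120 nM
compound 2, `CC(C)C[C@H](N)c1cc(C(F)(F)F)ccc1N1CCN(C(=O)CCC(N)=O)CC1`, this assay: a limit, > 10000 nM
compound 3, `CC(C)C[C@H](N)c1cc(C(F)(F)F)ccc1N1CCN(C(=O)CCNC2CCCCC2)CC1`, this assay: 4800 nM

In an assay on HEK293 cells for displacement of a labelled ligand from Melanocortin receptor 4 (Homo sapiens) (a lower number here means a stronger inhibitor, a higher number a weaker inhibitor), compound 1 gives 120 nM. Compound 2 gives only > 10000 nM in this assay, which is a limit of the assay and not a number (the limit of > 10000 nM in this assay, at which 1 of the 3 values shown sits). Compound 3 gives 4800 nM in this assay, the higher of the two numbers; its nearest neighbour is compound 1, with a 40-fold higher number from compound 1 to compound 3 (1.60 log units; beyond the scatter). Between the other two, an at least 2.0-fold lower number from compound 2 to compound 3 (0.31 log units; beyond the scatter).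

Compound 4, `COc1ccc(CC(C)C(=O)N2CCN(c3ccc(C(F)(F)F)cc3[C@@H](N)CC(C)C)CC2)cc1F`, differs from compound 3 in one place: 1-(3-fluoro-4-methoxybenzyl)ethyl in place of 2-(cyclohexylamino)ethyl on a carbonyl carbon. The entering group is the 1-(4-methoxybenzyl)ethyl of compound 1 carrying an added fluorine. For the measured compounds named here, the step that bears on this change is the one from compound 1 to compound 3, which was large; compound 4 essentially runs that step backwards. A large fall in the number is therefore expected, a 44-fold lower number from compound 3 to compound 4 (1.64 log units; beyond the scatter), landing close to compound 1. Compound 4 is estimated at 110 nM in this assay, within 40 nM to 300 nM.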

Compound 4, inhibition constant: 200 nM
Compound 4: the middle estimate sits 1.8-fold (0.26 log units) below what was measured, and the stated range covers the measured number.
By their numbers in this assay, from the lowest: compounds 1 and 4 (each within the scatter of the next); then compound 3. At a limit, above all of these: compound 2.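

Restoring the benzyl side chain recovers binding in this assay: a 24-fold lower number from compound 3 to compound 4 (1.38 log units; beyond the scatter), and an at least 50-fold lower number from compound 2 to compound 4 (1.69 log units; beyond the scatter). Compound 2 stands at a limit of the assay and not at a number: the limit of > 10000 nM in this assay, at which 1 of the 4 values shown sits. For the compounds shown here, what the earlier compounds did not show concerns the aromatic ring of the side chain, where fluoro in place of hydrogen gives a 1.7-fold higher number from compound 1 to compound 4 (0.22 log units; within the scatter), so this substitution is accepted without a change that can be read.

The compounds shown leave open whether a chlorine, a methyl group or a nitrile on that aromatic carbon would be accepted in the same way. They also leave open how much of the 1-(3-fluoro-4-methoxybenzyl)ethyl group is needed, for instance whether a hydroxyl could replace the methoxy or an unbranched chain could replace the branched one.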